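The compounds below may be only part of what the source reports. "The series", "measured", "known", "first", "only" and "open" are said of these compounds alone.

Three compounds share one core and differ only in the aryl group carried on the amide nitrogen at the far end of the chain. All were tested in an assay on isolated protein for binding affinity to interleukin-15 (Homo sapiens), read by surface plasmon resonance; a lower number here means tighter binding, a higher number weaker binding. Compound 1 `CCCOc1ccc(NC(=O)CCCCCCCSc2nnc(Cc3nn(C)c(=O)c4ccccc34)n2C)cc1` gives 19000 nM. Compound 2 `Cn1c(Cc2nn(C)c(=O)c3ccccc23)nnc1SCCCCCCCC(=O)Nc1ccc(Cl)cc1Cl` gives 19100 nM. Compound 3 `Cn1c(Cc2nn(C)c(=O)c3ccccc23)nnc1SCCCCCCCC(=O)Nc1ccc(Br)cc1Br` gives 11600 nM. Compound 3 stands at the low end of these three numbers, yet the steps of a 1.6-fold lower number from compound 1 to compound 3 (0.21 log units; within the scatter) and a 1.6-fold lower number from compound 2 to compound 3 (0.22 log units; within the scatter) both lie within the scatter, as does a 1.0-fold higher number from compound 1 to compound 2 (0.00 log units; within the scatter), so the three compounds cannot be told apart in this assay.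

Compound 4 `Cc1ccc(NC(=O)CCCCCCCSc2nnc(Cc3nn(C)c(=O)c4ccccc34)n2C)c(Cl)c1` continues the same kind of exchange: 2-chloro-4-methylphenyl in place of 2,4-dibromophenyl on an amide-type nitrogen. Going by the values given here, the steps that bear on it are those just described, in which swapping one aryl group for another on that nitrogen, whether 4-propoxyphenyl for 2,4-dichlorophenyl or 2,4-dichlorophenyl for 2,4-dibromophenyl, never moved the number beyond the scatter. With no sign that this position drives binding among the measured compounds, no step beyond the scatter is expected for a 1.3-fold higher number from compound 3 to compound 4 (0.11 log units; within the scatter). Compound 4 is therefore estimated at 15000 nM in this assay, with a range from 6000 nM to 40000 nM.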

Compound 4, dissociation constant: 24100 nM
For compound 4 the middle estimate is 1.6-fold (0.21 log units) below the measured one, within the range that was stated.
By their numbers in this assay, from the lowest: compounds 3, 1, 2 and 4 (each within the scatter of the next, the first and the last beyond it).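

In this assay, going by these compounds alone, the step of a 2.1-fold higher number from compound 3 to compound 4 (0.32 log units; beyond the scatter) is the first exchange on this amide-type nitrogen to pass the scatter, though only modestly, so the choice of aryl group can register in the binding number. The separation is confined to the two ends of the series, as compound 4 stays within the scatter of the other two compounds, with a 1.3-fold higher number from compound 2 to compound 4 (0.10 log units; within the scatter) and a 1.3-fold higher number from compound 1 to compound 4 (0.10 log units; within the scatter). Nothing available accounts for the gap between compound 3 and compound 4.

The exchange of 2,4-dibromophenyl for 2-chloro-4-methylphenyl alters both ring substituents at once, so the compounds shown do not tell whether one of them or the pair lies behind the step, and a 2-bromo-4-methylphenyl group on the same nitrogen would help divide it. All the groups here are substituted phenyl rings on the same chain, which leaves open what a carboxylic acid or an amine on that ring, a pyridine ring in its place, or a shorter or longer chain would do to the number.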